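The compounds below may be only part of what the source reports. "The series", "measured", "known", "first", "only" and "open" are said of these compounds alone.

In a functional assay on OVCAR-8 cells (Homo sapiens) (a lower number here means a stronger inhibitor of growth, a higher number a weaker inhibitor of growth), compound 1 `O=S(=O)(/C=C/c1ccc(F)cc1)Cc1ccc(Nc2ncnc3ccccc23)cc1` gives 2000 nM and compound 2 `O=S(=O)(/C=C/c1ccc(Cl)cc1Cl)Cc1ccc(Nc2ncnc3ccccc23)cc1` gives 4000 nM. For the measured compounds named here, these are the only two numbers so far, and they lie within the scatter of each other, so neither stands apart. Compound 3 `O=S(=O)(/C=C/c1ccc(F)cc1Cl)Cc1ccc(Nc2ncnc3ccccc23)cc1` is not yet measured. It departs from compound 2 by a single exchange, fluoro in place of chloro on an aromatic carbon, meta to a chloro group and para to a large group, turning 2,4-dichlorophenyl into 2-chloro-4-fluorophenyl. Going by the values given here, one measured step bears on this, the exchange of 4-fluorophenyl for 2,4-dichlorophenyl, which amounted to a 2.0-fold higher number from compound 1 to compound 2 (0.30 log units; within the scatter). Since that larger exchange stayed within the scatter, the smaller one is expected to do the same. The expected step is a 1.3-fold lower number from compound 2 to compound 3 (0.12 log units; within the scatter), with no real change anticipated in this assay. For compound 3 the estimated value is 3000 nM, with an expected range of 1300 nM to 7000 nM.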

Compound 3, concentration for 50% growth inhibition: 100000 nM
Compound 3: middle estimate off by 33-fold (1.52 log units), on the low side; measured number above the stated range.
By their numbers in this assay, from the lowest: compounds 1 and 2 (each within the scatter of the next); then compound 3.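

In this assay the aromatic carbon para to a large group and meta to a chloro group proves sensitive to its halogen: fluoro in place of chloro there gives a 25-fold higher number from compound 2 to compound 3 (1.40 log units; beyond the scatter) in the 2-chloro-4-fluorophenyl series member. Adding chloro to the 4-fluorophenyl ring gives a 50-fold higher number from compound 1 to compound 3 (1.70 log units; beyond the scatter) as well, so the two halogens are tolerated apart from this pairing and the loss appears only with 2-chloro-4-fluorophenyl, which the step between compound 1 and compound 2 gave no sign of. No measurement on hand accounts for this loss of growth inhibition.

Still open, going by these compounds, is whether the sharp drop is specific to fluoro at this carbon, or whether bromo, methyl or methoxy there, with the chloro group kept, would behave like compound 2 or like compound 3. A single cell line also leaves open whether the same gap appears in other growth assays.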